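This account rests on a few compounds, and the source may have more. Where it says the series, first, only, none or still open, it means among the compounds named here.

Compound 1, `Fc1ccc(/C=N/c2sc3c(c2-c2nc4ccccc4s2)CCCC3)cc1`: 230 ug/mL
Compound 2, `O=[N+]([O-])c1ccc(/C=N/c2sc3c(c2-c2nc4ccccc4s2)CCCC3)cc1`: 316 ug/mL
Compound 3, `C(=C/c1ccccc1)\C=N\c1sc2c(c1-c1nc3ccccc3s1)CCCC2`: 207 ug/mL

These three compounds share one core and differ only in the group attached to the carbon that carries a double bond to nitrogen. In an ADME assay on cells (Rhabdomyosarcoma cell, Homo sapiens) for cytotoxicity, read by MTT assay, with a stated time of 72 h (on this read-out lower numbers stand for higher toxicity in this test and higher numbers for lower toxicity in this test), compound 3 gives the smallest of the three numbers, yet its distance to each of the others stays within the usual scatter: the step from compound 1 to compound 3 is a 1.1-fold lower number from compound 1 to compound 3 (0.05 log units; within the scatter) and the step from compound 2 to compound 3 is a 1.5-fold lower number from compound 2 to compound 3 (0.18 log units; within the scatter), so nothing separates the three in this test.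

Compound 4, `Oc1ccccc1/C=N/c1sc2c(c1-c1nc3ccccc3s1)CCCC2`, has not yet been measured. The change from compound 3 is 2-hydroxyphenyl in place of 2-phenylethenyl on a carbon with a double bond to nitrogen. For the measured compounds named here, two measured steps bear on it directly, since each exchanges an aromatic ring for the 2-phenylethenyl group at this same place, and both, a 1.1-fold lower number from compound 1 to compound 3 (0.05 log units; within the scatter) and a 1.5-fold lower number from compound 2 to compound 3 (0.18 log units; within the scatter), lie within the scatter. The swap of a substituent on that aromatic ring, a 1.4-fold higher number from compound 1 to compound 2 (0.14 log units; within the scatter), is also within the scatter. Going by the values given here, no measured compound carries a hydroxy group, so that part of the change has no direct precedent. On these grounds the expected step is a 1.1-fold higher number from compound 3 to compound 4 (0.05 log units; within the scatter), that is, nothing beyond the scatter. Compound 4 is therefore estimated at 230 ug/mL in this assay, with a range of 120 ug/mL to 420 ug/mL.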

Compound 4, half-maximal cytotoxic concentration: 42.4 ug/mL
Beside the measured number, compound 4's estimate is 5.4-fold (0.73 log units) above it; the measured number lies below the stated range.
By their numbers in this assay, from the lowest: compound 4; then compounds 3, 1 and 2 (each within the scatter of the next).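

At this position, 4-fluorophenyl, 4-nitrophenyl and 2-phenylethenyl gave numbers within the scatter of one another, so the place seemed to tolerate a change of group without any effect on the read-out. For the compounds shown here, the 2-hydroxyphenyl group is the first here to move the number beyond the scatter in this assay, with a 4.9-fold lower number from compound 3 to compound 4 (0.69 log units; beyond the scatter) and a 5.4-fold lower number from compound 1 to compound 4 (0.73 log units; beyond the scatter) and a 7.5-fold lower number from compound 2 to compound 4 (0.87 log units; beyond the scatter), and in this test a lower number stands for higher toxicity. Compound 4 is also the only one of the four with a hydroxy group, so the change goes with that group, but no measurement here explains why the number falls.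

The compounds shown include no unsubstituted phenyl at this place and no ring carrying a methoxy group or an amine instead of the hydroxy group, so they cannot tell whether the hydroxy group itself matters or whether other ring substituents would give the same result. They also leave open whether a hydroxy group at another ring position would lower the number as well, and whether the same change would hold on a different core.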